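Nitro in place of trifluoromethoxy: step from compound 1

This account rests on a few compounds, and the source may have more. Where it says the series, first, only, none or still open, it means among the compounds named here.

Measured so far:
Compound 1 `CC(c1ccc(-c2ccccc2)c(F)c1)c1nnc2n1N=C(c1ccc(OC(F)(F)F)cc1)CS2` gives 8400 nM in a functional assay on Huh-7 cells (Homo sapiens) for inhibition, read by sulforhodamine B assay, with a stated time of 72 h; on this read-out lower numbers stand for stronger inhibition and higher numbers for weaker inhibition.
Compound 2 `COc1ccc2cc(C(C)c3nnc4n3N=C(c3ccc(C)cc3)CS4)ccc2c1` gives 8200 nM in this assay.
Compound 3 `CC(C)Cc1ccc(C(C)c2nnc3n2N=C(c2ccc(F)cc2)CS3)cc1` gives 7800 nM in this assay.

Compound 1 carries the highest of the three numbers, but its gap to compound 2 and to compound 3 lies within the scatter, so the three values show no order among themselves; all sit in the same band.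

The unmeasured compound 4 `CC(c1ccc(-c2ccccc2)c(F)c1)c1nnc2n1N=C(c1ccc([N+](=O)[O-])cc1)CS2` differs from compound 1 in one place: nitro in place of trifluoromethoxy on an aromatic carbon. Within the data shown here, no pair of measured compounds differs in a single place, so no measured step can guide this change; the only support is the narrow band that compound 1, compound 2 and compound 3 occupy with their varied substitution on the same ring. The expected step in this assay is therefore none beyond the scatter, with direction undetermined. The step expected from compound 1 to compound 4 is a 1.1-fold lower number from compound 1 to compound 4 (0.02 log units; within the scatter). For compound 4 the estimate in this assay is 8000 nM, within a range from 3000 nM to 22000 nM.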

Compound 4, half-maximal inhibitory concentration: 4300 nM
For compound 4 the middle estimate is 1.9-fold (0.27 log units) above the measured one; the range from low to high includes it.
By their numbers in this assay, from the lowest: compounds 4, 3, 2 and 1 (each within the scatter of the next).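

Among these compounds, this is the first single-place comparison: replacing 4-(trifluoromethoxy)phenyl with 4-nitrophenyl gives a 2.0-fold lower number from compound 1 to compound 4 (0.29 log units; within the scatter) in this assay and so provides a direct reading at this position. The aromatic carbon para to a large group accepts nitro in place of trifluoromethoxy with no step beyond the scatter, although the entering group differs in its heavy atoms and hydrogen-bond acceptors. With the rest of compound 1 held constant, this single pair therefore shows no clear sensitivity to this change. No available evidence accounts for the size of this step.

The compounds shown leave open whether an amine or a carboxylic acid on this aromatic carbon would produce a step beyond the scatter. They also leave open whether nitro would give a similar step with the other substituents of compound 2 or compound 3.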